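The source may report more compounds than this note shows. Statements on the series, on what has been measured and on what is new or still open speak of the compounds shown alone.

Measured so far:
- Compound 1, `O=C(Nc1ccc(O)c(C(=O)O)c1)c1ccc(NC(=O)c2ccco2)cc1`: 100%
- Compound 2, `CCC(=O)Nc1ccc(C(=O)Nc2ccc(C(=O)O)c(O)c2)cc1`: 70%

In an assay on isolated protein for inhibition of NAD-dependent protein deacylase sirtuin-6 (Homo sapiens), read by fluorescence, tested at 200 uM (a higher number here means more inhibition at the concentration tested (going by the name of the read-out), a lower number less inhibition), compound 1 gives 100%, while compound 2 gives 70%. Compound 2 therefore stands lowest of the two numbers, and its nearest neighbour, compound 1, lies higher by a margin beyond the usual scatter of this assay.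

Compound 3 `O=C(Nc1ccc(C(=O)O)c(O)c1)c1ccc(N2C(=O)CCS2(=O)=O)cc1` has not yet been measured. It differs from compound 2 in one place: a group of 8 heavy atoms (3 carbon, 1 nitrogen, 3 oxygen, 1 sulfur; one five-membered non-aromatic ring with 2 hetero atoms) in place of a group of 5 heavy atoms (3 carbon, 1 nitrogen, 1 oxygen; no ring), on an aromatic carbon. Among the compounds with values here, no measured pair shows a change of this kind, so there is no step to lean on. A modest rise in inhibition is expected, but one that may not stand beyond the scatter, so the step from compound 2 to compound 3 is estimated at a number 5 percentage points higher from compound 2 to compound 3 (within the scatter). Compound 3 is accordingly expected to give about 75% in this assay, within a range from 45% to 100%.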

Compound 3, a percentage reported as inhibition, at one concentration (the size of the read-out at that concentration, not a potency): 100%
For compound 3 the middle estimate is 25 percentage points below the measured one, and the stated range covers the measured number.
By their numbers in this assay, from the lowest: compound 2; then compounds 1 and 3 (each within the scatter of the next).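

In this assay the propanoylamino group on the aromatic carbon para to a large group can be replaced by the larger five-membered ring group, and the change gives a number 30 percentage points higher from compound 2 to compound 3 (beyond the scatter) at the one concentration tested. The inhibition in this assay is higher with the entering group, which has 0 hydrogen-bond donors, than with the propanoylamino group, which has 1 hydrogen-bond donor. Nothing measured here explains the rise.

The compounds shown do not separate the contribution of the ring from that of the sulfur and its oxygens, so a comparison with a plain five-membered lactam, which has no sulfur, would be needed. As far as these compounds go, how a simple amine, a carboxylic acid or a longer chain would behave at this position also remains open.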